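Changing the ring nitrogen group of compound 1

A few compounds are considered here, and "the series" means these few. Any claim that something is new, unique, unknown or untested is made for them only; others in the source may bear on it.

Three compounds have been measured in a functional assay (strain AB) with Danio rerio as the target, read by microscopy, with a stated time of 1 h; a lower number here means that less compound is needed, a higher number that more compound is needed for the effect:
- compound 1 `CC(C)[N+]1(C)CCc2c(sc(NC(=O)Nc3ccc(Cl)cc3)c2C(N)=O)C1` gives 960 nM
- compound 2 `CCN1CCc2c(sc(NC(=O)Nc3ccc(Cl)cc3)c2C(N)=O)C1` gives 3120 nM
- compound 3 `CC(C)(C)OC(=O)CCN1CCc2c(sc(NC(=O)Nc3ccc(Cl)cc3)c2C(N)=O)C1` gives 1100 nM

Compound 1 and compound 3 lie within the usual scatter of each other, and compound 2 has a higher number than both, beyond the scatter. So compound 1 shares the low end of this small set with compound 3.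

The next compound is compound 4 `C[N+]1(CC2CCCC2)CCc2c(sc(NC(=O)Nc3ccc(Cl)cc3)c2C(N)=O)C1`, which has cyclopentylmethyl in place of isopropyl on an amine nitrogen in a ring. Within the data shown here, no measured step swaps one group for another on the nitrogen of compound 1, so the guidance is thin. Going by a 2.8-fold lower number from compound 2 to compound 3 (0.45 log units; beyond the scatter), the only measured step that also enlarges the group on an amine nitrogen in a ring, a small move toward a lower number in this assay or none beyond the scatter is expected. The expected step is small (a 1.2-fold lower number from compound 1 to compound 4 (0.08 log units; within the scatter)). Compound 4 is estimated at 800 nM (expected range 300 nM to 2400 nM).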

Compound 4, half-maximal effective concentration: 200 nM
Estimate against measurement, compound 4: 4.0-fold (0.60 log units) above, and the stated range ends above it.
By their numbers in this assay, from the lowest: compound 4; then compounds 1 and 3 (each within the scatter of the next); then compound 2.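

Replacing isopropyl with cyclopentylmethyl gives a 4.8-fold lower number from compound 1 to compound 4 (0.68 log units; beyond the scatter) in this assay. Among these compounds, this is the first measured swap of one group for another on the nitrogen of compound 1, and it shows that this position responds to the group it carries, with a step beyond the scatter and a ring-bearing group giving the lower number. No supporting measurement is available to explain this step.

This single step changes the carbon count and adds a ring together, so the compounds shown do not separate these two changes. Going by these compounds, a straight hexyl chain or a benzyl group on the same nitrogen would help show whether the ring itself matters, and how far the trend extends remains open.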